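This account rests on a few compounds, and the source may have more. Where it says the series, first, only, none or still open, it means among the compounds named here.

Measured compounds:
compound 1 `COCOCc1cc(OC)ccc1-c1cc2ccccc2c(=O)[nH]1` — 27500 nM
compound 2 `C=CCn1c(-c2cc(OC)c(OC)cc2C=C)cc2ccccc2c1=O` — 75200 nM
compound 3 `C=CCn1c(-c2ccc(OC)cc2C=C)cc2ccccc2c1=O` — 22800 nM

These three compounds were tested in a functional assay on HCT-15 cells (Homo sapiens) for cytotoxicity, read by MTT assay, with a stated time of 48 h; a lower number here means a stronger inhibitor, a higher number a weaker inhibitor. In this assay compound 1 gives 27500 nM, compound 2 gives 75200 nM and compound 3 gives 22800 nM. Compound 3 and compound 2 differ in one place only, (methoxy in place of hydrogen on an aromatic carbon), and this change made a step of a 3.3-fold higher number from compound 3 to compound 2 (0.52 log units; beyond the scatter). Compound 1 and compound 3 share no such single point of difference; the difference between the two cores is not broken down here, and their two values lie close to each other.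

Compound 4 `COCOCc1cc(OC)c(OC)cc1-c1cc2ccccc2c(=O)[nH]1` has not yet been measured. It differs from compound 1 by methoxy in place of hydrogen on an aromatic carbon. For the measured compounds named here, this is the same kind of change as the one from compound 3 to compound 2, but not the same change: in compound 2 the new methoxy sits para to a vinyl group, whereas in compound 4 it sits para to a (methoxymethoxy)methyl group, and the cores of the two pairs differ as well.

Going by the values given here, with only one measured example of this kind of change to go on, the step from compound 1 to compound 4 is expected to be about a 2.7-fold higher number from compound 1 to compound 4 (0.44 log units; beyond the scatter), resting on the step of a 3.3-fold higher number from compound 3 to compound 2 (0.52 log units; beyond the scatter) seen in the other pair. On that basis compound 4 is estimated to give about 75000 nM in this assay, most likely between 25000 nM and 200000 nM.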

Compound 4, half-maximal inhibitory concentration: 73700 nM
Compound 4: the middle estimate sits 1.0-fold (0.01 log units) above what was measured, within the range that was stated.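

The added methoxy gives a 2.7-fold higher number from compound 1 to compound 4 (0.43 log units; beyond the scatter) in this assay, so on the core of compound 1 this change again goes with a weaker inhibitor, as it did in the earlier pair. Set side by side, the two steps point the same way and do not differ in size by more than repeated measurements of this kind would: the same change on two cores in this assay, a 3.3-fold higher number (0.52 log units; beyond the scatter) from compound 3 to compound 2 and a 2.7-fold higher number (0.43 log units; beyond the scatter) from compound 1 to compound 4, 1.2-fold (0.09 log units) apart, within the scatter of two such steps. This shows that, in these two pairs, the change carried over from one core to the other with much the same result, but two pairs cannot show that it would do so on every core in the series, and they do not explain why the number rises.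

The compounds shown have only a methoxy as the added group, so it remains open whether a hydroxyl group, a fluorine atom, an amine or a longer chain such as ethoxy at that place would raise the number in the same way. On these data alone, it also remains open whether the step would look the same on cells other than those of this one assay, since every number here comes from this assay.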